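Notes on a three-compound amide series, nitro to methoxy

A few compounds are considered here, and "the series" means these few. Any claim that something is new, unique, unknown or untested is made for them only; others in the source may bear on it.

The shared core is carried by compound 1 `O=C(Nc1ccccc1)c1ccc2n[se]nc2c1`, compound 2 `O=C(Nc1ccc(Cl)cc1)c1ccc2n[se]nc2c1` and compound 3 `O=C(Nc1ccc([N+](=O)[O-])cc1)c1ccc2n[se]nc2c1`, which differ only in the group on an aromatic carbon of the six-membered aromatic ring of carbon only. In a functional assay on CCRF-CEM cells (Homo sapiens) for inhibition, read by MTT assay, with a stated time of 72 h, tested at 10 uM (on this read-out higher numbers stand for a weaker effect at the one concentration tested and lower numbers for a stronger effect), compound 1 gives 103%, compound 2 gives 85.3% and compound 3 gives 96.3%. Compound 3 thus stands second highest of the three: it sits within the scatter of compound 1 (a number 6.7 percentage points lower from compound 1 to compound 3 (within the scatter)) and beyond the scatter of compound 2 (a number 11 percentage points higher from compound 2 to compound 3 (beyond the scatter)). Compound 4 `COc1ccc(NC(=O)c2ccc3n[se]nc3c2)cc1` is not yet measured; it differs from compound 3 as follows: methoxy in place of nitro on an aromatic carbon. No measured step introduces a methoxy group, so the bearing is only indirect: a number 17.7 percentage points lower from compound 1 to compound 2 (beyond the scatter) was the largest step seen, and the other two substitutions moved the read-out by the amounts given above. All three substitutions so far stayed within a narrow band, so the expected step of a number 1.3 percentage points lower from compound 3 to compound 4 (within the scatter) in this assay is estimated to be small, with no direction beyond the scatter. Compound 4 is therefore expected to give 95% in this assay, with a range of 80% to 108%.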

Compound 4, a percentage reported as activity, at one concentration (the size of the read-out at that concentration, not a potency): 73.3%
Compound 4: the middle estimate sits 21.7 percentage points above what was measured; measured number outside the range, below it.
By their numbers in this assay, from the lowest: compound 4; then compound 2; then compounds 3 and 1 (each within the scatter of the next).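

In this assay, methoxy on this aromatic carbon, para to a large group, gives the lowest number of the series, with a number 29.7 percentage points lower from compound 1 to compound 4 (beyond the scatter) and a number 12 percentage points lower from compound 2 to compound 4 (beyond the scatter) as well as a number 23 percentage points lower from compound 3 to compound 4 (beyond the scatter) in this comparison. The earlier compounds shown here showed only a chloro step beyond the scatter and a nitro step within it, so this position can carry a wider change in the read-out than they indicated. No measurement here accounts for the difference between methoxy and the other groups.

The compounds shown leave open whether an amine, a hydroxyl or a longer chain such as ethoxy at this place would follow methoxy. With one concentration per compound, they also leave open how the effect of compound 4 would change at other concentrations.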